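The compounds below may be only part of what the source reports. "The series", "measured", "known", "first", "only" and "open" are said of these compounds alone.

Compound 1 `CCOC(=O)C1=C(S[C@@H]2CN[C@H](C(=O)Nc3cccc(C(=O)OCC)c3)C2)[C@H](C)[C@@H]2[C@@H]([C@@H](C)OC(=O)CC)C(=O)N12` and compound 2 `CCOC(=O)C1=C(S[C@@H]2CN[C@H](C(=O)Nc3cccc(C(=O)OCC)c3)C2)[C@H](C)[C@@H]2[C@@H]([C@@H](C)O)C(=O)N12` are the two measured compounds here. In an ADME assay on the whole organism (plasma, strain Beagle) for pharmacokinetics, with Canis familiaris (Canis lupus familiaris) as the target, read by LC-MS, with a stated time of 8 h, at a dose of 10 mg/kg by the intraduodenal route (on this read-out higher numbers stand for higher exposure at the dose given and lower numbers for lower exposure), compound 1 gives "below limit of detection" (no number reported), an entry without a number. In this assay, going by the values given here, compound 2 gives 2660 ng.h/mL, the only number in hand, so it stands alone rather than high or low. Compound 3 `CCOC(=O)C1=C(S[C@@H]2CN[C@H](C(=O)Nc3cccc(C(=O)OCC)c3)C2)[C@H](C)[C@@H]2[C@@H]([C@@H](C)OC(=O)[C@@H](N)C(C)C)C(=O)N12` carries (1-amino-2-methylpropyl)carbonyl in place of hydrogen on an oxygen on a saturated carbon. Among the compounds with values here, no step between measured compounds is given, so the expectation rests on this change alone; the step of a 3.0-fold lower number from compound 2 to compound 3 (0.47 log units; beyond the scatter) is expected to run downward, beyond the usual scatter. Compound 3 is estimated to give 900 ng.h/mL, between 150 ng.h/mL and 3500 ng.h/mL.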

Compound 3, area under the concentration-time curve: "below limit of detection" (no number reported)
Nothing numeric was reported for compound 3, and the estimate cannot be compared.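

Going by these compounds alone, compound 3 has no number in this assay and so no step from compound 2 to compound 3 can be read. Why compound 1 and compound 3 lack numbers stays open, with no evidence bearing on it.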